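This account rests on a few compounds, and the source may have more. Where it says the series, first, only, none or still open, it means among the compounds named here.

Compound 2 is `CCOC(=O)CN(c1ccccc1)C1c2cc(C#N)ccc2OC(C)(C)C1O`. In a functional assay (aorta) with Rattus norvegicus as the target (on this read-out higher numbers stand for weaker inhibition and lower numbers for stronger inhibition), compound 2 gives > 30000 nM, which is a limit of the assay and not a number. Going by the values given here, the only other compound measured here, compound 1 `COC(=O)c1cc2ccccc2n1[C@@H]1c2cc(C#N)ccc2OC(C)(C)[C@H]1O`, gives in this assay a value of 33000 nM. Compound 3 `CCOC(=O)CN(c1ccccc1)[C@H]1c2cc(C#N)ccc2OC(C)(C)[C@@H]1O` differs from compound 2 in this way: the two compounds have the same atoms and bonds; at least one stereo element is drawn with a configuration in one of them and without one in the other: 2 of 2 stereo elements differ; a stereocentre at a saturated ring carbon is drawn without a configuration in compound 2 and S in compound 3; a stereocentre at a saturated ring carbon is drawn without a configuration in compound 2 and R in compound 3. Among the compounds with values here, because compound 2 sits at the limit of > 30000 nM in this assay, at which 1 of the 2 values shown sits, no measured step shows how drawing the two configurations changes the read-out. Compound 3 is expected in this assay at 30000 nM, between 8000 nM and 100000 nM. The step of a number no higher from compound 2 to compound 3 (the limit leaves the size open) is expected to be none beyond the scatter.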

Compound 3, half-maximal inhibitory concentration: > 30000 nM
Compound 3: a limit, no number (the forecaster's own chance of this, stated with the estimate: 60%); the middle value sits exactly at the limit.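

Going by these compounds alone, no step from compound 2 to compound 3 can be read, because both stand at a limit of the assay and not at a number: the limit of > 30000 nM in this assay, at which 2 of the 3 values shown sit. As far as these compounds go, whether drawing the two configurations changes the read-out at all stays open.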